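From pyridin-2-yl to pyridin-3-yl in compound 3

The source may hold more compounds than are shown below. What is called first, only, known or untested is meant among the compounds shown, and "the series" means these compounds.

Compound 1 `COc1ccccc1OCC1SCCN1C(=O)CC(C)=O`: 30 mg/kg
Compound 2 `COc1ccccc1OCC1SCCN1C(=O)CC(=O)NCc1ccccn1`: 26 mg/kg
Compound 3 `COc1ccccc1OCC1SCCN1C(=O)CC(=O)NCc1cccnc1`: not yet measured

In a functional assay on the whole organism for inhibition, with Cavia porcellus as the target (on this read-out higher numbers stand for an effect only at larger amounts of compound and lower numbers for an effect already at smaller amounts), compound 2 gives 26 mg/kg, which cannot be told apart from the value of compound 1. Compound 3 differs from compound 2 by one exchange: pyridin-3-yl in place of pyridin-2-yl on a saturated chain carbon bound to an amide-type nitrogen. Going by the values given here, no measured step tests this exchange directly. Among the compounds with values here, the only step at hand, a 1.2-fold lower number from compound 1 to compound 2 (0.06 log units; within the scatter), replaced a whole group and still stayed small, so a swap of the same atoms is not expected to do more. The expected change is no change at the digits printed from compound 2 to compound 3 (within the scatter), nothing beyond the scatter. Compound 3 is estimated at 26 mg/kg, with an expected range of 12 mg/kg to 55 mg/kg.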

Compound 3, dose for half-maximal effect: 57 mg/kg
Estimate against measurement, compound 3: 2.2-fold (0.34 log units) below, and the stated range ends below it.
By their numbers in this assay, from the lowest: compounds 2, 1 and 3 (each within the scatter of the next, the first and the last beyond it).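

In this assay the placing of the ring nitrogen matters: pyridin-3-yl in place of pyridin-2-yl on a saturated chain carbon bound to an amide-type nitrogen gives a 2.2-fold higher number from compound 2 to compound 3 (0.34 log units; beyond the scatter) and so a modest shift from atoms that are merely joined differently. The whole-group exchange of methyl on a carbonyl carbon for ((pyridin-3-yl)methyl)amino gives a 1.9-fold higher number from compound 1 to compound 3 (0.28 log units; within the scatter) and stays smaller. Nothing at hand explains the difference between these two pyridinyl groups. As far as these compounds go, how pyridin-4-yl or phenyl would read at this place remains open, as does the effect of a longer chain carrying the pyridine ring.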